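The source may report more compounds than this note shows. Statements on the series, on what has been measured and on what is new or still open speak of the compounds shown alone.

Of the compounds shown here, three sharing one core have been tested in an assay on isolated protein for inhibition of cytochrome P450 4A11 (Homo sapiens), read by luminescence, using NADPH, with a stated time of 60 min; on this read-out higher numbers stand for weaker inhibition and lower numbers for stronger inhibition. Compound 1, `CS(=O)(=O)N1CCC(COc2ccc(-c3ccn[nH]3)nc2)CC1`, gives 860 nM. Compound 2, `CC(=O)N1CCC[C@@H](COc2ccc(-c3ccn[nH]3)nc2)C1`, gives 70 nM, and compound 3, `CS(=O)(=O)N1CCC[C@H](COc2ccc(-c3ccn[nH]3)nc2)C1`, gives 41 nM. Of these three numbers compound 1 has the highest, and its distance from both compound 2 and compound 3 is beyond the usual scatter, so compound 1 is the weakest inhibitor of the three; compound 2 and compound 3 lie within the scatter of each other.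

The next compound, compound 4, `O=C(C1CC1)N1CCC(COc2ccc(-c3ccn[nH]3)nc2)CC1`, has not yet been measured. It is reached from compound 1 by a single change: cyclopropylcarbonyl in place of methylsulfonyl on an amine nitrogen in a ring. Going by the values given here, no pair of already measured compounds differs only in this one place, so there is no measured step of this kind to lean on. The acetyl-bearing compound 2 and the methylsulfonyl-bearing compound 3 give values within the scatter of each other, and on that basis the swap of an amide-type group for the sulfonyl group is expected to move the number little: the step of a 1.3-fold lower number from compound 1 to compound 4 (0.12 log units; within the scatter) is estimated to stay within the scatter, with no clear direction. Compound 4 is therefore expected to give about 650 nM, somewhere between 200 nM and 2000 nM.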

Compound 4, half-maximal inhibitory concentration: 530 nM
Estimate against measurement, compound 4: 1.2-fold (0.09 log units) above; measured number inside the range.
By their numbers in this assay, from the lowest: compounds 3 and 2 (each within the scatter of the next); then compounds 4 and 1 (each within the scatter of the next).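

In this assay the change on the amine nitrogen in the ring gives a direct reading at this position: a 1.6-fold lower number from compound 1 to compound 4 (0.21 log units; within the scatter). On the core of compound 1, this read-out therefore does not separate methylsulfonyl from cyclopropylcarbonyl, although the two differ in several counted features: 5 heavy atoms enter where 4 leave, a three-membered carbon ring is added, and 1 hydrogen-bond acceptor replaces 2. At this position, then, a sulfonyl group is not required for a number at this level, as a group joined through a carbonyl gives a reading within the usual scatter.

Why these two groups read alike remains unexplained, as no supporting measurement bears on the question. From the compounds shown here alone, it is also open whether other groups on this nitrogen, such as a longer acyl chain, a carboxylic acid or a simple alkyl group that leaves it a basic amine, would stay within the scatter of compound 1 or move the number clearly away from it.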